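A few compounds are considered here, and "the series" means these few. Any claim that something is new, unique, unknown or untested is made for them only; others in the source may bear on it.

Measured so far:
compound 1 `COc1ccc(C(=O)Nc2c(F)cccc2Cl)cc1OC1CCCC1` with 240 nM
compound 2 `COc1ccc(C(=O)Nc2cccnc2)cc1OC1CCCC1` with 550 nM
compound 3 `COc1ccc(C(=O)Nc2ncccc2C)cc1OC1CCCC1` with 3100 nM

In an assay on isolated protein for inhibition of phosphodiesterase 4A (Sus scrofa) (a lower number here means a stronger inhibitor, a higher number a weaker inhibitor), compound 3 gives the highest number of the three, with compound 2 nearest at a 5.6-fold higher number from compound 2 to compound 3 (0.75 log units; beyond the scatter) and compound 1 furthest at a 13-fold higher number from compound 1 to compound 3 (1.11 log units; beyond the scatter). Compound 4 `COc1ccc(C(=O)Nc2c(C)nsc2C)cc1OC1CCCC1` differs from compound 3 by 3,5-dimethyl-1,2-thiazol-4-yl in place of 3-methylpyridin-2-yl on an amide-type nitrogen. Among the compounds with values here, the only steps that bear on this are the exchanges of the ring on the amide nitrogen, which moved this assay by a 2.3-fold higher number from compound 1 to compound 2 (0.36 log units; beyond the scatter) and a 13-fold higher number from compound 1 to compound 3 (1.11 log units; beyond the scatter); each such exchange shifted the number beyond the scatter. Since compound 3 is the weakest measured, a new ring is expected to lower the number, estimated as a 4.4-fold lower number from compound 3 to compound 4 (0.65 log units; beyond the scatter). For compound 4 the expected value in this assay is 700 nM, within 150 nM to 3000 nM.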

Compound 4, half-maximal inhibitory concentration: 500 nM
For compound 4 the middle estimate is 1.4-fold (0.15 log units) above the measured one; the measured number falls inside the stated range.
By their numbers in this assay, from the lowest: compound 1; then compounds 4 and 2 (each within the scatter of the next); then compound 3.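

In this assay the exchange to 3,5-dimethyl-1,2-thiazol-4-yl gives a 6.2-fold lower number from compound 3 to compound 4 (0.79 log units; beyond the scatter) and shows that the amide-type nitrogen can carry a five-membered aromatic ring without the loss seen with 3-methylpyridin-2-yl. That ring matches pyridin-3-yl, with a 1.1-fold lower number from compound 2 to compound 4 (0.04 log units; within the scatter) and so no order between them, but falls short of 2-chloro-6-fluorophenyl, with a 2.1-fold higher number from compound 1 to compound 4 (0.32 log units; beyond the scatter) as the gap. Nothing measured here gives a reason for these shifts.

As far as these compounds go, it remains open whether the two methyl groups on the new ring matter, and whether an amine or a carboxylic acid in their place would shift the number.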